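A few compounds are considered here, and "the series" means these few. Any claim that something is new, unique, unknown or untested is made for them only; others in the source may bear on it.

Measured so far in a functional assay on HEK293 cells (Homo sapiens) for cytotoxicity (a lower number here means that less compound is tolerated, a higher number that more compound is tolerated), each value a limit of the assay and not a number:

compound 1 `COc1ccc([C@H]2CC(=O)N(c3cccc(C#N)c3)C2)cc1OC1CCCC1` gives > 10000 nM
compound 2 `COc1ccc([C@H]2CC(=O)N(c3cccc([S+](C)[O-])c3)C2)cc1OC1CCCC1` gives > 10000 nM
compound 3 `COc1ccc([C@H]2CC(=O)N(c3cccc(NCCCc4ccccc4)c3)C2)cc1OC1CCCC1` gives > 10000 nM

Compound 3 stands at > 10000 nM, which is only a limit. The series offers the limit of > 10000 nM in this assay, at which 3 of the 3 values shown sit, and nothing finer, so compound 3 cannot be placed against the other two.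

Compound 4 `CCCCNc1cccc(N2C[C@@H](c3ccc(OC)c(OC4CCCC4)c3)CC2=O)c1` has not yet been measured. It differs from compound 3 by methyl in place of phenyl on a saturated chain carbon, three bonds along the chain from a nitrogen on an aromatic ring. This is methyl in place of phenyl on a saturated chain carbon, three bonds along the chain from a nitrogen on an aromatic ring; cut further out, it reads 3-phenylpropyl to butyl.

The closest evidence is a step that the two limits leave unreadable from compound 1 to compound 3, together with a step that the two limits leave unreadable from compound 2 to compound 3, since both change the group at the same place. A third step is a step that the two limits leave unreadable from compound 1 to compound 2. None of them gives a size or a direction.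

No step beyond the scatter is therefore expected in this assay, and no direction can be assigned. The expected step is a step that the limit leaves unreadable from compound 3 to compound 4. For compound 4 the estimated value is 15000 nM, with an expected range from 7000 nM to 40000 nM, and a reported limit is the likeliest result.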

Compound 4, half-maximal cytotoxic concentration: > 10000 nM
Compound 4 ended at the assay's limit (the forecaster's own chance of this, stated with the estimate: 85%); the middle value is on the limit's open side.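

In this assay compound 4 gives > 10000 nM, which is a limit of the assay. No step can be read between compound 4 and compound 1, compound 2 or compound 3, and the series offers only this: the limit of > 10000 nM in this assay, at which 4 of the 4 values shown sit.

The compounds shown leave open what concentration of any of them would be cytotoxic, and whether these groups differ at all.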